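The source may hold more compounds than are shown below. What is called first, only, known or untested is meant among the compounds shown, and "the series" means these compounds.

Measured compounds in the series so far:

Compound 1 `CCS(=O)(=O)Nc1ccc(Oc2ccc(C#N)cc2)c(-c2cn(C)c(=O)c3[nH]ccc23)c1` — in an ADME assay on microsomes from liver (Homo sapiens) for metabolic stability, read by HPLC, using NADPH, with stated times of 5 min and 60 min, tested at 10 uM (a higher number here means faster removal of the compound, a lower number slower removal), compound 1 gives 41.7 mL/min/kg.
Compound 2 `Cn1cc(-c2cc(NS(C)(=O)=O)ccc2Oc2ccc(F)cc2F)c2cc[nH]c2c1=O` — in this assay compound 2 gives 155 mL/min/kg.

Going by the values given here, compound 1 stands at the lowest of the two numbers in this assay; the only other compound, compound 2, sits at a higher number, and the gap between the two lies beyond the usual scatter. Among the compounds with values here, no pair differing in a single place has been measured, so nothing can yet be read about the size of any one structural change.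

Compound 3 `CCS(=O)(=O)Nc1ccc(OC2CCC(N(C)C)CC2)c(-c2cn(C)c(=O)c3[nH]ccc23)c1` is the next compound in line for this assay. It differs from compound 1 in one place: 4-(dimethylamino)cyclohexyl in place of 4-cyanophenyl on an oxygen on an aromatic ring. The rest of the shared core, the ethylsulfonamide and the ether oxygen are kept.

Within the data shown here, with no measured single-point step to lean on, the expected change from compound 1 to compound 3 is taken as a 1.4-fold lower number from compound 1 to compound 3 (0.14 log units; within the scatter), a step that is not expected to go beyond the scatter, if anything towards a slightly lower number. Compound 3 is accordingly estimated at 30 mL/min/kg, with a range from 12 mL/min/kg to 75 mL/min/kg.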

Compound 3, clearance: < 26.7 mL/min/kg
Compound 3: no number, only a limit; the forecaster's own chance of this, stated with the estimate: 5%; middle value at least 1.1-fold (0.05 log units) from the limit.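

In this assay, compound 3 carries a limit of the assay and not a number: the limit of < 26.7 mL/min/kg in this assay, at which 1 of the 3 values shown sits.

Even so, this gives the series its only readable single-place step, at the group on an oxygen on an aromatic ring: 4-(dimethylamino)cyclohexyl in place of 4-cyanophenyl gives an at least 1.5-fold lower number from compound 1 to compound 3 (0.19 log units; that floor lies within the scatter). The position therefore accepts a six-membered non-aromatic ring of carbon carrying a dimethylamino group without a rise in clearance, which compounds 1 and 2 alone could not show, although the size of the drop remains unresolved and its floor lies within the scatter.

From the compounds shown here alone, the change replaces the ring and its substituent together, so the contribution of each stays open; 4-(dimethylamino)phenyl or 4-cyanocyclohexyl on the same oxygen would separate the two. Going by these compounds, how far clearance falls with the amine kept on this position also stays open, as does whether a smaller amine such as a 4-aminocyclohexyl group or a carboxylic acid in that place would read the same way in this assay.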